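The compounds below may be only part of what the source reports. "The series", "measured", "known", "first", "only" and "open" are said of these compounds alone.

In an ADME assay on HepG2 cells (Homo sapiens) for cytotoxicity, read by resazurin assay, with a stated time of 48 h (on this read-out higher numbers stand for an effect only at larger amounts of compound and lower numbers for an effect already at smaller amounts), compound 1 `Cc1nc(C)c(C(=O)Nc2ccc(F)c(-c3nc4ncc(-c5cccnc5Cl)cn4n3)c2)o1` gives > 50000 nM, which is a limit of the assay and not a number. Compound 2 `O=C(Nc1ccc(F)c(-c2nc3ncc(-c4cncc(F)c4)cc3[nH]2)c1)N1CCCC1` gives > 50000 nM, also a limit, so it stands only at that limit and has no exact value. Within the data shown here, the record so far comes down to the limit of > 50000 nM in this assay, at which 2 of the 2 values shown sit, and it holds no step between measured compounds. Compound 3 `O=C(Nc1ccc(F)c(-c2nc3ncc(-c4cccnc4F)cc3[nH]2)c1)N1CCCC1` has the same atoms as compound 2, joined differently, with 2-fluoropyridin-3-yl in place of 5-fluoropyridin-3-yl on an aromatic carbon. In this assay the expected outcome is a number no higher from compound 2 to compound 3 (the limit leaves the size open), which means no change beyond the scatter. This expectation rests on compound 2 with its limit of > 50000 nM. Compound 3 is estimated at 50000 nM, with an expected range from 25000 nM to 100000 nM.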

Compound 3, half-maximal effective concentration: > 50000 nM
Compound 3 was reported as a limit (the forecaster's own chance of this, stated with the estimate: 80%); the middle value sits exactly at the limit.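

Compound 3, like compound 2, is reported only as a limit in this assay, so no step can be read between the two. The compounds shown leave open where any of them would reach its half-maximal effect, as all stand at one limit: the limit of > 50000 nM in this assay, at which 3 of the 3 values shown sit.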